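The source may report more compounds than this note shows. Statements on the series, on what has been measured and on what is new or still open speak of the compounds shown alone.

Compound 1 `CC(C)c1c(C(=O)NCc2ccccc2)nn(-c2ccc(F)cc2)c1OC[C@@H](O)C[C@@H](O)CC(=O)O` stands highest of the two numbers measured in an assay on microsomes from liver for inhibition of 3-hydroxy-3-methylglutaryl-coenzyme A reductase (Rattus norvegicus) (a higher number here means a weaker inhibitor, a lower number a stronger inhibitor), where compound 1 gives 3.8 nM. Compound 2 `CC(C)c1c(C(=O)NCc2cccc(F)c2F)nn(-c2ccc(F)cc2)c1OC[C@@H](O)C[C@@H](O)CC(=O)O` gives 2 nM, and the step of a 1.9-fold lower number from compound 1 to compound 2 (0.28 log units; within the scatter) lies within the scatter. Compound 3 `CC(C)c1c(C(=O)N2CCC[C@H](c3ccccc3)C2)nn(-c2ccc(F)cc2)c1OC[C@@H](O)C[C@@H](O)CC(=O)O` differs from compound 1 by 3-phenylpiperidin-1-yl in place of benzylamino on a carbonyl carbon. For the measured compounds named here, no measured step touches the amide nitrogen itself; the one known step concerns only the benzyl substitution, so there is nothing to anchor this change. The author expects a step of a 2.4-fold higher number from compound 1 to compound 3 (0.37 log units; beyond the scatter), a modest rise beyond the scatter, and estimates that compound 3 gives 9 nM in this assay, within 2 nM to 40 nM.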

Compound 3, half-maximal inhibitory concentration: 4.8 nM
Estimate against measurement, compound 3: 1.9-fold (0.27 log units) above; measured number inside the range.
By their numbers in this assay, from the lowest: compounds 2, 1 and 3 (each within the scatter of the next, the first and the last beyond it).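

In this assay, 3-phenylpiperidin-1-yl in place of benzylamino on the carbonyl carbon gives a 1.3-fold higher number from compound 1 to compound 3 (0.10 log units; within the scatter), so this position tolerates losing the amide hydrogen and carrying a larger ring-bearing group. Against the difluorinated benzyl amide, the change gives a 2.4-fold higher number from compound 2 to compound 3 (0.38 log units; beyond the scatter), the first step here beyond the scatter. No evidence is available to explain either step.

On these data alone, it remains open how the opposite configuration of the 3-phenylpiperidin-1-yl group would read. Also open, as far as these compounds go, is whether a 3-(2,3-difluorophenyl)piperidin-1-yl group or a morpholin-4-yl group would hold this number.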